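A few compounds are considered here, and "the series" means these few. Any claim that something is new, unique, unknown or untested is made for them only; others in the source may bear on it.

Compound 1 `CC1CCN(c2c(S(=O)(=O)c3ccc(F)c(Cl)c3)cnc3cc(F)ccc23)CC1` stands highest of the three measured compounds in an assay on isolated protein for displacement of a labelled ligand from metabotropic glutamate receptor 5 (Homo sapiens), with a stated time of 60 min, tested at 1 uM (a higher number here means more inhibition at the concentration tested (going by the name of the read-out), a lower number less inhibition), where compound 1 gives 94%. Compound 2 `COc1ccc(S(=O)(=O)c2cnc3cc(F)ccc3c2N2CCC(C)CC2)cc1` gives 90% and compound 3 `Cc1cc(C)cc(S(=O)(=O)c2cnc3cc(F)ccc3c2N2CCC(C)CC2)c1` gives 80%. The steps of a number 4 percentage points lower from compound 1 to compound 2 (within the scatter) and a number 14 percentage points lower from compound 1 to compound 3 (beyond the scatter) alter only the ring attached to the sulfonyl sulfur. Compound 4 `CC1CCN(c2c(S(=O)(=O)c3ccc(F)c(Cl)c3)cnc3cc(Cl)ccc23)CC1` differs from compound 1 at another place: chloro in place of fluoro on an aromatic carbon. Within the data shown here, no measured step touches this part of the shared core, so the measured steps give no direct guide to the size of the change in this assay. All three measured numbers are high, and exchanging chloro for fluoro at this site gives no reason to expect a step beyond the scatter. Compound 4 is therefore expected to give about 90%, between 78% and 97%. The step of a number 4 percentage points lower from compound 1 to compound 4 (within the scatter) is expected to stay within the scatter.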

Compound 4, a percentage reported as inhibition, at one concentration (the size of the read-out at that concentration, not a potency): 94%
Compound 4: the middle estimate sits 4 percentage points below what was measured, within the range that was stated.
By their numbers in this assay, from the lowest: compounds 3, 2, 1 and 4 (each within the scatter of the next, the first and the last beyond it).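

Placing chloro instead of fluoro on this aromatic carbon of the shared core gives no change at the digits printed from compound 1 to compound 4 (within the scatter) in this assay. Unlike the earlier steps, which altered only the ring on the sulfonyl sulfur, this one shows that the number can hold when this other part of the molecule is changed, at least for this pair of halogens. Nothing available explains why the number holds. Going by these compounds, what remains open is how a nitrile or a carboxylic acid at this same carbon would read in this assay.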